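Aryl ether exchange on the shared core

This account rests on a few compounds, and the source may have more. Where it says the series, first, only, none or still open, it means among the compounds named here.

Measured so far in a functional assay on isolated protein for agonist activity at Glucose-dependent insulinotropic receptor (Homo sapiens), read by HTRF and cAMP accumulation; a higher number here means that more compound is needed for the effect, a lower number that less compound is needed:
compound 1 `CC(C)(C)OC(=O)N1CCC(O[C@H]2CC[C@H](Oc3ccc(S(C)(=O)=O)cc3)CC2)CC1`: 16.1 nM
compound 2 `CC(C)(C)OC(=O)N1CCC(O[C@H]2CC[C@H](Oc3ccc(S(C)(=O)=O)c(F)c3)CC2)CC1`: 52 nM

Compound 1 gives the lowest number of the two; compound 2 stands at 52 nM, the step being a 3.2-fold higher number from compound 1 to compound 2 (0.51 log units; beyond the scatter). Compound 3 `CC(C)(C)OC(=O)N1CCC(O[C@H]2CC[C@H](Oc3cnc(C#N)cn3)CC2)CC1` arises from compound 1 by 5-cyanopyrazin-2-yl in place of 4-(methylsulfonyl)phenyl on an oxygen on a saturated carbon. Within the data shown here, no measured step bears on this exchange of the whole aromatic group: the one known step concerns only a fluoro added to the ring that here leaves. The expectation therefore rests on compound 1 alone, with wide uncertainty in either direction. Compound 3 is estimated at 12 nM, range 3 nM to 60 nM, which is expected to be a 1.3-fold lower number from compound 1 to compound 3 (0.13 log units; within the scatter).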

Compound 3, half-maximal effective concentration: 8.3 nM
Beside the measured number, compound 3's estimate is 1.4-fold (0.16 log units) above it, within the range that was stated.
By their numbers in this assay, from the lowest: compounds 3 and 1 (each within the scatter of the next); then compound 2.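

In this assay, the whole aromatic group on the oxygen can be exchanged, not only decorated: 5-cyanopyrazin-2-yl in place of 4-(methylsulfonyl)phenyl gives a 1.9-fold lower number from compound 1 to compound 3 (0.29 log units; within the scatter), so for this pair the sulfur-bearing group is not needed for the response. A ring with 2 hetero atoms and a nitrile thus serves here on the shared core. No data on hand account for this result.

Open, going by these compounds, is which part of the entering group matters, which 4-cyanophenyl and unsubstituted pyrazin-2-yl would separate. Also open, on these data alone, is how an amine or a carboxylic acid on that ring would read.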